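The source may hold more compounds than are shown below. What is called first, only, known or untested is meant among the compounds shown, and "the series" means these compounds.

- compound 1 `Cc1cc(-c2ccccc2)n2nc(C(=O)Nc3sc4c(c3C(N)=O)CCCC4)nc2n1` gives > 250000 nM
- compound 2 `Cc1cc(-c2ccccc2)n2nc(C(=O)Nc3sc4c(c3C(N)=O)CCC4)nc2n1` gives > 250000 nM
- compound 3 `Cc1cc(-c2ccccc2)n2nc(C(=O)Nc3sc(C)c(C)c3C(N)=O)nc2n1` gives > 250000 nM

In an ADME assay on MDCK cells (Canis lupus familiaris) for cytotoxicity, read by MTT assay, with a stated time of 48 h (on this read-out lower numbers stand for higher toxicity in this test and higher numbers for lower toxicity in this test), compound 1 gives > 250000 nM, which is a limit of the test and not a number. Compound 1 stands with the other two compounds, as the values show (the limit of > 250000 nM in this assay, at which 3 of the 3 values shown sit). Compound 4 `CCC1CCc2c(sc(NC(=O)c3nc4nc(C)cc(-c5ccccc5)n4n3)c2C(N)=O)C1` differs from compound 1 by ethyl in place of hydrogen on a saturated ring carbon, with ethyl in place of hydrogen on a saturated ring carbon. Among the measured compounds shown here, no two measured compounds differ in only one place, so this expectation rests on little. A small move toward lower numbers in this assay is expected, perhaps none beyond the usual scatter, and the estimated change is an at least 1.2-fold lower number from compound 1 to compound 4 (0.09 log units; that floor lies within the scatter). For compound 4 the expected value is 200000 nM, with an estimated range of 90000 nM to 250000 nM.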

Compound 4, half-maximal cytotoxic concentration: > 250000 nM
Compound 4 was reported as a limit; the forecaster's own chance of this, stated with the estimate: 60%; middle value at least 1.2-fold (0.09 log units) from the limit.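

No step can be read from compound 1 to compound 4, because both values are limits and not numbers: the limit of > 250000 nM in this assay, at which 4 of the 4 values shown sit. Still open, from the compounds shown here alone, is how far each compound lies from that limit in this assay and whether any change to the shared core gives a lower number.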